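Benzamide series: para-substituent steps toward compound 4

A few compounds are considered here, and "the series" means these few. Any claim that something is new, unique, unknown or untested is made for them only; others in the source may bear on it.

Measured compounds:
- compound 1, `CCc1ccc(C(=O)Nc2ccc(C)c(-n3cc(-c4cccnc4)cn3)c2)cc1`: 6520 nM
- compound 2, `COc1ccc(C(=O)Nc2ccc(C)c(-n3cc(-c4cccnc4)cn3)c2)cc1`: 18300 nM
- compound 3, `CCN(CC)Cc1ccc(C(=O)Nc2ccc(C)c(-n3cc(-c4cccnc4)cn3)c2)cc1`: 3260 nM

All three share one core and differ only in the group on the benzamide ring. In a functional assay on K562 cells (Homo sapiens) for inhibition, read by MTT assay, with a stated time of 48 h (a lower number here means a stronger inhibitor, a higher number a weaker inhibitor), compound 1 gives 6520 nM, the second highest of the three numbers. Its neighbours: a 2.8-fold higher number from compound 1 to compound 2 (0.45 log units; beyond the scatter), and a 2.0-fold lower number from compound 1 to compound 3 (0.30 log units; within the scatter). Between the other two, a 5.6-fold lower number from compound 2 to compound 3 (0.75 log units; beyond the scatter).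

The next compound, compound 4, `Cc1ccc(NC(=O)c2ccc(CN3CCCN(C)CC3)cc2)cc1-n1cc(-c2cccnc2)cn1`, follows the step from compound 1 as 4-methyl-1,4-diazepan-1-yl in place of methyl on a saturated chain carbon bound to an aromatic carbon.

Within the data shown here, the step that bears directly on this is the one from compound 1 to compound 3, where a diethylamino group replaced methyl at the same saturated chain carbon bound to an aromatic carbon; that step was a 2.0-fold lower number from compound 1 to compound 3 (0.30 log units; within the scatter), i.e. within the scatter. The step from compound 2 to compound 3 was larger, a 5.6-fold lower number from compound 2 to compound 3 (0.75 log units; beyond the scatter), but it starts from the methoxy compound and does not carry over to compound 1 directly. Since the change in compound 4 also places a saturated amine ring on that chain carbon, the expected outcome is a step of about the same size and direction as from compound 1 to compound 3: a lower number, but not clearly beyond the scatter. The estimated step for compound 4 in this assay is a 1.9-fold lower number from compound 1 to compound 4 (0.27 log units; within the scatter).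

Compound 4 is therefore expected at 3500 nM, with a range of 1200 nM to 10000 nM.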

Compound 4, half-maximal inhibitory concentration: 8650 nM
The estimate for compound 4 lay 2.5-fold (0.39 log units) below the measured number, and the stated range covers the measured number.
By their numbers in this assay, from the lowest: compounds 3, 1 and 4 (each within the scatter of the next, the first and the last beyond it); then compound 2.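

In this assay, the 4-methyl-1,4-diazepan-1-yl ring on the saturated chain carbon bound to an aromatic carbon leaves compound 4 within the scatter of compound 1 (a 1.3-fold higher number from compound 1 to compound 4 (0.12 log units; within the scatter)), while compound 4 still separates from the methoxy compound (a 2.1-fold lower number from compound 2 to compound 4 (0.33 log units; beyond the scatter)). The new information is that the choice of amine at this carbon can be read: exchanging diethylamino for the ring gives a step beyond the scatter (a 2.7-fold higher number from compound 3 to compound 4 (0.42 log units; beyond the scatter)), even though compound 3 and compound 4 each lie within the scatter of compound 1. No measurement shown accounts for the separation between these two amine groups.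

As far as these compounds go, whether this separation follows the seven-membered ring, its second nitrogen or its methyl group stays open, as no six-membered amine such as 4-methylpiperazin-1-yl or morpholin-4-yl appears on that carbon. From the compounds shown here alone, a smaller open-chain amine such as dimethylamino is also absent, so it remains unknown whether such a group would fall with compound 3 or with compound 4.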